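This account rests on a few compounds, and the source may have more. Where it says the series, first, only, none or still open, it means among the compounds named here.

Compound 1 (`Cc1nc(Nc2ccc(Cl)cc2)sc1C(=O)/C=C/c1ccccc1`) gives 24600 nM in a functional assay on PC-3 cells (Homo sapiens) for cytotoxicity, read by MTT assay; a higher number here means a weaker inhibitor, a lower number a stronger inhibitor.
Compound 2 (`Cc1nc(Nc2cccc(Cl)c2)sc1C(=O)/C=C/c1ccccc1`) reaches only the limit of this assay, recorded as > 25000 nM.
Compound 3 (`COc1cccc(/C=C/C(=O)c2sc(Nc3ccc(C)cc3)nc2C)c1`) likewise reaches only the limit of this assay, recorded as > 25000 nM.

Compound 3 therefore has no measured number at all, only a limit, and it shares that position with compound 2, as the limit of > 25000 nM in this assay, at which 2 of the 3 values shown sit, shows. The step to compound 4 (`Cc1ccc(Nc2nc(C)c(C(=O)/C=C/c3ccccc3)s2)cc1`) is hydrogen in place of methoxy on an aromatic carbon. Going by the values given here, the only measured step in this set, an at least 1.0-fold higher number from compound 1 to compound 2 (0.00 log units; that floor lies within the scatter), concerns a different change, and it lands on the floor of the assay without leaving the scatter, so it offers no guide to the size or direction of the present change. Among the compounds with values here, with compound 3 already at the limit and no step of this kind measured, compound 4 is expected to sit in the same region, with a step that the limit leaves unreadable from compound 3 to compound 4 as the estimated step, meaning no change beyond the scatter. In this assay compound 4 is estimated at 30000 nM, within a range of 12000 nM to 80000 nM, most likely reported again only as a limit.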

Compound 4, half-maximal inhibitory concentration: > 25000 nM
Compound 4 was reported as a limit; the forecaster's own chance of this, stated with the estimate: 70%; the middle value is on the limit's open side.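

Taking the methoxy off does not bring the compound into a readable range: in this assay compound 4 is again only a limit, > 25000 nM. Going by these compounds alone, its steps from compound 2 and compound 3 cannot be read, as both ends of each are limits, while the one readable step is an at least 1.0-fold higher number from compound 1 to compound 4 (0.00 log units; that floor lies within the scatter), for methyl in place of chloro on an aromatic carbon. The values now gather at one end of the scale: the limit of > 25000 nM in this assay, at which 3 of the 4 values shown sit.

On these data alone, neither compound 3 nor compound 4 gives an actual number, so what the methoxy contributes in this assay stays open. Also open, as far as these compounds go, is whether another group at that place on the phenyl ring, such as an amine or a carboxylic acid, would give a measurable value clearly under the limit.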